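The source may hold more compounds than are shown below. What is called first, only, known or untested is meant among the compounds shown, and "the series" means these compounds.

Working notes on the series, read in a functional assay on HepG2 cells (Homo sapiens) for antiproliferative activity, read by MTT assay, with a stated time of 24 h; a lower number here means a stronger inhibitor, a higher number a weaker inhibitor. Compound 1 (`C=CCOc1ccc2c(=O)c(-c3cc(OC)c(OC)cc3OC)coc2c1`) gives 3450 nM, compound 2 (`COc1cc(OC)c(-c2coc3cc(OCc4ccccc4F)ccc3c2=O)cc1OC`) gives 1280 nM and compound 3 (`COc1cc(OC)c(-c2coc3cc(OCc4ccc(Br)cc4)ccc3c2=O)cc1OC`) gives 1050 nM. Compound 3 has the lowest number of the three, but only the gap to compound 1 is beyond the scatter: a 3.3-fold lower number from compound 1 to compound 3 (0.52 log units; beyond the scatter). Its gap to compound 2 is within the scatter: a 1.2-fold lower number from compound 2 to compound 3 (0.09 log units; within the scatter).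

Compound 4 (`COc1cc(OC)c(-c2coc3cc(OCc4ccc([N+](=O)[O-])cc4)ccc3c2=O)cc1OC`) carries nitro in place of bromo on an aromatic carbon, para to a large group: nitro in place of bromo on an aromatic carbon. Among the measured compounds shown here, no measured pair makes this exact exchange. For the measured compounds named here, the nearest precedent is the swap of 2-fluorophenyl for 4-bromophenyl, a 1.2-fold lower number from compound 2 to compound 3 (0.09 log units; within the scatter), which stayed within the scatter. The modest steps, a 2.7-fold lower number from compound 1 to compound 2 (0.43 log units; beyond the scatter) and a 3.3-fold lower number from compound 1 to compound 3 (0.52 log units; beyond the scatter), replace vinyl with a substituted phenyl, and compound 4 keeps such a phenyl. No step beyond the scatter is therefore expected in this assay. The estimated change is a 1.1-fold higher number from compound 3 to compound 4 (0.06 log units; within the scatter). The estimate for compound 4 is 1200 nM, with an expected range of 500 nM to 2900 nM.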

Compound 4, half-maximal inhibitory concentration: 2500 nM
The estimate for compound 4 lay 2.1-fold (0.32 log units) below the measured number; measured number inside the range.
By their numbers in this assay, from the lowest: compounds 3, 2, 4 and 1 (each within the scatter of the next, the first and the last beyond it).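

In this assay, the aromatic carbon para to a large group responds to what it carries: nitro in place of bromo gives a 2.4-fold higher number from compound 3 to compound 4 (0.38 log units; beyond the scatter), whereas the earlier exchange between substituted phenyls stayed within the scatter. A substituted phenyl alone therefore does not secure a step beyond the scatter from vinyl: 4-nitrophenyl gives a 1.4-fold lower number from compound 1 to compound 4 (0.14 log units; within the scatter), and in place of 2-fluorophenyl it gives a 2.0-fold higher number from compound 2 to compound 4 (0.29 log units; within the scatter), both within the scatter. No accompanying data bear on this step, and its origin remains unexplained.

Going by these compounds, whether the step is particular to nitro or extends to other groups on this carbon remains open; an amine, a nitrile or a carboxylic acid there would test this. Also open, on these data alone, is whether the same exchange would give a similar step on a different aromatic carbon of the benzyl ring.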